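The source may report more compounds than this note shows. Statements on the series, on what has been measured and on what is new or still open speak of the compounds shown alone.

Within the data shown here, in an ADME assay on NHDF cells (Homo sapiens) for cytotoxicity, read by MTT assay, with a stated time of 72 h (a lower number here means a stronger inhibitor, a higher number a weaker inhibitor), compound 1 `COc1cccc(/C=C2\CCC/C(=C\c3ccccc3Cl)C2=O)c1OC` gives 44200 nM and compound 2 `COc1cccc(/C=C2\CCC/C(=C\c3cccc(Cl)c3)C2=O)c1OC` gives 21400 nM as the lower of the two numbers so far. Compound 3 `COc1cccc(/C=C2\CCC/C(=C\c3ccc(Cl)cc3)C2=O)c1OC` follows with 4-chlorophenyl in place of 3-chlorophenyl on a double-bonded chain carbon bound to a double-bonded ring carbon as its change, 4-chlorophenyl in place of 3-chlorophenyl on a double-bonded chain carbon bound to a double-bonded ring carbon. Among the measured compounds shown here, the one measured step at this place is a 2.1-fold lower number from compound 1 to compound 2 (0.32 log units; beyond the scatter) and it is modest, only just beyond the scatter. For the measured compounds named here, no measured compound yet carries 4-chlorophenyl, so that single step gives no direction for the next change, and no step beyond the scatter is expected in this assay here. The estimated move is a 1.0-fold lower number from compound 2 to compound 3 (0.01 log units; within the scatter) as expected from that one modest precedent. For compound 3 the expected value is 21000 nM with an estimated range from 9500 nM to 45000 nM on present evidence.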

Compound 3, half-maximal inhibitory concentration: 18600 nM
Beside the measured number, compound 3's estimate is 1.1-fold (0.05 log units) above it; the range from low to high includes it.
By their numbers in this assay, from the lowest: compounds 3 and 2 (each within the scatter of the next); then compound 1.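

In this assay, 4-chlorophenyl in place of 3-chlorophenyl on a double-bonded chain carbon bound to a double-bonded ring carbon gives a 1.2-fold lower number from compound 2 to compound 3 (0.06 log units; within the scatter), so these two placements of the chlorine cannot be told apart. 4-chlorophenyl in place of 2-chlorophenyl gives a 2.4-fold lower number from compound 1 to compound 3 (0.38 log units; beyond the scatter), a modest step that, with the earlier one, leaves compound 1 alone at the higher end, while compound 2 and compound 3 stay together. No supporting data bear on this difference.

Open, from the compounds shown here alone, is whether the level seen with 3-chlorophenyl and 4-chlorophenyl holds for other groups at this place, such as unsubstituted phenyl, 4-fluorophenyl or a phenyl carrying an amine or a carboxylic acid. Also open, going by these compounds, is how far the two methoxy groups on the other aryl ring contribute to these numbers.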